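Amine tail variation in the shared core series

The source may hold more compounds than are shown below. What is called first, only, known or untested is meant among the compounds shown, and "the series" means these compounds.

Of the compounds shown here, three of the shared core have been measured in a functional assay on A-375 cells (Homo sapiens) for cytotoxicity, read by MTT assay, with a stated time of 72 h; on this read-out higher numbers stand for weaker inhibition and lower numbers for stronger inhibition. Compound 1 `CN1CCN(CCCCCn2c3c(c4ccccc42)C(=O)c2c[n+]([O-])c4ccccc4c2C3=O)CC1` gives 1710 nM. Compound 2 `O=C1c2c[n+]([O-])c3ccccc3c2C(=O)c2c1c1ccccc1n2Cc1cn(C[C@@H](O)CO)nn1` gives 140 nM. Compound 3 `O=C1c2c[n+]([O-])c3ccccc3c2C(=O)c2c1c1ccccc1n2CCCCN1CCCCC1` gives 190 nM, the second highest of the three numbers; its nearest neighbour is compound 2, and the step of a 1.4-fold higher number from compound 2 to compound 3 (0.13 log units; within the scatter) lies within the scatter, so no order between these two can be read. The gap to compound 1 is larger, as a 9.0-fold lower number from compound 1 to compound 3 (0.95 log units; beyond the scatter) shows. The remaining step, a 12-fold lower number from compound 1 to compound 2 (1.09 log units; beyond the scatter), is the largest in the set.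

Compound 4 `O=C1c2c[n+]([O-])c3ccccc3c2C(=O)c2c1c1ccccc1n2CCN1CCCC1` is not yet measured. Its change from compound 3 is pyrrolidin-1-yl in place of 2-(piperidin-1-yl)ethyl on a saturated chain carbon, two bonds along the chain from an aromatic nitrogen. Within the data shown here, no measured step addresses a shortening of the chain together with a smaller ring. The steps of a 12-fold lower number from compound 1 to compound 2 (1.09 log units; beyond the scatter) and a 9.0-fold lower number from compound 1 to compound 3 (0.95 log units; beyond the scatter) both remove the 4-(4-methylpiperazin-1-yl)butyl tail of compound 1, and the step of a 1.4-fold higher number from compound 2 to compound 3 (0.13 log units; within the scatter) exchanges the 1-(2,3-dihydroxypropyl)-1H-1,2,3-triazol-4-yl tail for the 3-(piperidin-1-yl)propyl tail without leaving the scatter. The large numbers belong only to compound 1, so the amine tails that remain in compounds 2 and 3 give no reason to expect a big move. The step of a 1.3-fold higher number from compound 3 to compound 4 (0.12 log units; within the scatter) is expected to stay within the scatter. For compound 4 the estimate in this assay is 250 nM, with a range from 100 nM to 700 nM.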

Compound 4, half-maximal inhibitory concentration: 430 nM
Estimate against measurement, compound 4: 1.7-fold (0.24 log units) below, within the range that was stated.
By their numbers in this assay, from the lowest: compounds 2 and 3 (each within the scatter of the next); then compound 4; then compound 1.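

In this assay, among these compounds, the shift from the 4-(piperidin-1-yl)butyl tail to the 2-(pyrrolidin-1-yl)ethyl tail gives a 2.3-fold higher number from compound 3 to compound 4 (0.35 log units; beyond the scatter), the first step beyond the scatter among the compounds other than compound 1, so the amine tails at this position can no longer be treated as interchangeable. Compound 4 also separates from the triazole-bearing compound, with a 3.1-fold higher number from compound 2 to compound 4 (0.49 log units; beyond the scatter), while remaining clear of the 4-(4-methylpiperazin-1-yl)butyl tail, with a 4.0-fold lower number from compound 1 to compound 4 (0.60 log units; beyond the scatter), which places it in an intermediate position in the series and shows that a tail change away from compound 1 can also move the number beyond the scatter. No measurement available here accounts for these steps.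

Going by these compounds, whether the shorter chain or the smaller ring carries the step remains open, as the two change together from compound 3 to compound 4; a 2-(piperidin-1-yl)ethyl tail or a 4-(pyrrolidin-1-yl)butyl tail on the shared core would separate them. Also open, on these data alone, is how a morpholine ring or a primary amine at the end of the chain would read here.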